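The source may report more compounds than this note shows. Statements on the series, on what has been measured and on what is new or still open speak of the compounds shown alone.

Measured so far in a functional assay on LNCaP cells (Homo sapiens) for antiproliferative activity, read by propidium iodide staining, with a stated time of 96 h; on this read-out higher numbers stand for weaker inhibition and lower numbers for stronger inhibition:
compound 1 `CC(O)(COc1cccc(C(F)(F)F)c1)C(=O)Nc1ccc(S(F)(F)(F)(F)F)cc1`: 24700 nM
compound 2 `CC(O)(COc1cc(C(F)(F)F)cc(C(F)(F)F)c1)C(=O)Nc1ccc(S(F)(F)(F)(F)F)cc1`: 2300 nM
compound 3 `CC(O)(COc1cccc(C(F)(F)F)c1)C(=O)Nc1cccc(S(F)(F)(F)(F)F)c1`: 28800 nM

Compound 2 carries on the core of compound 1 the change (trifluoromethyl in place of hydrogen on an aromatic carbon). In this assay this gave an 11-fold lower number from compound 1 to compound 2 (1.03 log units; beyond the scatter). Compound 3 is built from the same atoms as compound 1, joined differently; the difference between the two cores is not broken down here. In this assay compound 3 and compound 1 give numbers within the scatter of each other.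

Compound 4 `CC(O)(COc1cc(C(F)(F)F)cc(C(F)(F)F)c1)C(=O)Nc1cccc(S(F)(F)(F)(F)F)c1` is not yet measured. It carries on the core of compound 3 the change (trifluoromethyl in place of hydrogen on an aromatic carbon), the same change as from compound 1 to compound 2. The expected step is a 10-fold lower number from compound 3 to compound 4 (1.01 log units; beyond the scatter), because an 11-fold lower number from compound 1 to compound 2 (1.03 log units; beyond the scatter) was seen on the same change and compound 3 starts from a number within the scatter of compound 1. Compound 4 is therefore expected to give 2800 nM, in the range 1000 nM to 8000 nM.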

Compound 4, half-maximal inhibitory concentration: 2800 nM
Estimate against measurement, compound 4: no gap at the digits printed; the measured number falls inside the stated range.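

In this assay, trifluoromethyl in place of hydrogen on an aromatic carbon gives a 10-fold lower number from compound 3 to compound 4 (1.01 log units; beyond the scatter). Set beside the earlier step, the size of the change holds on both cores, with no difference beyond the scatter: the same change on two cores in this assay, an 11-fold lower number (1.03 log units; beyond the scatter) from compound 1 to compound 2 and a 10-fold lower number (1.01 log units; beyond the scatter) from compound 3 to compound 4, 1.0-fold (0.02 log units) apart, within the scatter of two such steps. This shows that the step carries across these two cores, which start within the scatter of each other, but it does not show that it would carry to a core with a clearly different starting number, nor does it explain why the step arises.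

Still open, from the compounds shown here alone, is whether a nitrile, a methoxy group or an amine on the same aromatic carbon would give a step of similar size. Also open, going by these compounds, is whether the step would hold on a core with a longer chain in place of the methyl group.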